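Pyrazolyl-enone series: aryl swap on the carbonyl carbon

A few compounds are considered here, and "the series" means these few. Any claim that something is new, unique, unknown or untested is made for them only; others in the source may bear on it.

Measured so far:
compound 1, `COc1cc(-c2cc(/C=C/C(=O)c3ccc(N)cc3)[nH]n2)cc(OC)c1OC` — 1740 nM
compound 2, `COc1ccc(-c2cc(/C=C/C(=O)c3cc(OC)c(OC)c(OC)c3)[nH]n2)cc1OC` — 1750 nM

Compound 1 has been tested in a functional assay on COLO 205 cells (Homo sapiens) for inhibition, read by sulforhodamine B assay, with a stated time of 48 h (a lower number here means a stronger inhibitor of growth, a higher number a weaker inhibitor of growth), where compound 1 gives 1740 nM. Going by the values given here, compound 2, the only other measured member, gives 1750 nM in this assay, a number that lies within the scatter of the value of compound 1; the two compounds cannot be separated on these data, and no step between them is given.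

Compound 3 is `COc1ccc(C(=O)/C=C/c2cc(-c3cc(OC)c(OC)c(OC)c3)n[nH]2)cc1OC`, not yet measured. It departs from compound 1 in one place: 3,4-dimethoxyphenyl in place of 4-aminophenyl on a carbonyl carbon. Among the compounds with values here, no measured pair in this set differs by such a change, so no step can be drawn on for its size. The two measured compounds, which differ in several places at once, give the same number within the scatter, which gives no ground for expecting a large shift from this single exchange. The step from compound 1 to compound 3 in this assay is therefore expected to be a 1.0-fold lower number from compound 1 to compound 3 (0.01 log units; within the scatter), that is, none beyond the scatter. Compound 3 is expected to give about 1700 nM in this assay, with a range from 600 nM to 5000 nM.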

Compound 3, concentration for 50% growth inhibition: 1740 nM
For compound 3 the middle estimate is 1.0-fold (0.01 log units) below the measured one, within the range that was stated.
By their numbers in this assay, from the lowest: compounds 1, 3 and 2 (each within the scatter of the next).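

Going by these compounds alone, this pair gives the first reading at a single place: in this assay, 3,4-dimethoxyphenyl in place of 4-aminophenyl on a carbonyl carbon gives no change at the digits printed from compound 1 to compound 3 (within the scatter) on the shared core. The earlier compounds shown here differ in several places at once, whereas here one exchange replaces a group of 7 heavy atoms, 1 hydrogen-bond donor and 1 hydrogen-bond acceptor with one of 10 heavy atoms, 0 hydrogen-bond donors and 2 hydrogen-bond acceptors, and the growth-inhibition read-out does not separate the two groups. No supporting measurement bears on why these two groups read alike.

From the compounds shown here alone, both groups seen at this position are six-membered aromatic rings of carbon only, so it remains open whether the same flat reading would hold for a carboxylic acid, a longer alkyl chain or a simple unsubstituted phenyl on the carbonyl carbon. Within the data shown here, also open is whether this exchange would read the same on a core changed elsewhere, since only one single-place pair is available in this assay so far.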